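The source may report more compounds than this note shows. Statements on the series, on what has been measured and on what is new or still open speak of the compounds shown alone.

Measured compounds:
compound 1 `CCOC(=O)C1=C(C)N/C(=C/c2cc(C)n(-c3ccc(Cl)cc3)c2C)C1=O`, which in a physicochemical assay for lipophilicity, read by HPLC, at pH 7.4 (a lower number here means a more polar compound, a higher number a more lipophilic compound), gives 3.4;
compound 2 `CCOC(=O)C1=C(C)N/C(=C/c2cc(C)n(-c3cccc(OC)c3)c2C)C1=O`, which in this assay gives 2.9;
compound 3 `CCOC(=O)C1=C(C)N/C(=C/c2cc(C)n(-c3ccc(SC)cc3)c2C)C1=O`, for which this assay reports "not determined" (no result reported).

For the measured compounds named here, compound 3 therefore stands on no number of its own; the only numbers at hand are those of compound 1 and compound 2, which differ only in the group on the aromatic nitrogen. Going by the values given here, the one step between measured compounds, a number 0.50 log units lower from compound 1 to compound 2 (beyond the scatter), shows that exchanging that group can move the read-out by a modest but real amount.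

Compound 4 `CCOC(=O)C1=C(C)N/C(=C/c2cc(C)n(-c3cccnc3)c2C)C1=O` differs from compound 3 in the same place: pyridin-3-yl in place of 4-(methylsulfanyl)phenyl on an aromatic nitrogen. Among the compounds with values here, no measured step matches this exchange, and compound 3 itself carries no value, so the expectation rests on the two measured compounds alone. Given that compound 2 gives 2.9 and compound 1 gives 3.4, compound 4 is expected to come out below both, with a downward step rather than none.

The estimate for compound 4 in this assay is 2.2.
For compound 4 the expected range runs from 1.5 to 2.9.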

Compound 4, distribution coefficient: 2.1
For compound 4 the middle estimate is 0.10 log units above the measured one, within the range that was stated.
By their numbers in this assay, from the lowest: compound 4; then compound 2; then compound 1.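

The group on the aromatic nitrogen can move the read-out further than the 3-methoxyphenyl and 4-chlorophenyl compounds alone showed: in this assay, pyridin-3-yl gives a number 0.80 log units lower from compound 2 to compound 4 (beyond the scatter) and a number 1.30 log units lower from compound 1 to compound 4 (beyond the scatter). Among the three compounds with numbers, compound 4, whose ring carries 1 hetero atom, therefore sits lowest, while the step from compound 3 cannot be read because compound 3 has no number. Nothing at hand accounts for the size of these steps.

As far as these compounds go, it remains open whether the lower value of compound 4 goes with the ring nitrogen itself or with the absence of a further group on the ring, which an unsubstituted phenyl would help to separate. Also open, from the compounds shown here alone, is whether pyridin-2-yl or pyridin-4-yl at this place would give a similar number.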